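Working notes: from compound 2 to compound 4

A few compounds are considered here, and "the series" means these few. Any claim that something is new, unique, unknown or untested is made for them only; others in the source may bear on it.

Measured compounds:
compound 1 `COc1ccc(-c2cc(/C=C/C(=O)c3ccc(N)cc3)[nH]n2)cc1` — 2560 nM
compound 2 `COc1cc(-c2cc(/C=C/C(=O)c3ccc(N)cc3)[nH]n2)cc(OC)c1OC` — 2860 nM
compound 3 `COc1cc(-c2cc(/C=C/C(=O)c3ccc(F)c(F)c3)[nH]n2)cc(OC)c1OC` — 14200 nM

In a functional assay on UO-31 cells (Homo sapiens) for inhibition, read by sulforhodamine B assay, with a stated time of 48 h (a lower number here means a stronger inhibitor of growth, a higher number a weaker inhibitor of growth), compound 2 gives 2860 nM, the second highest of the three numbers. Its nearest neighbour is compound 1, which gives 2560 nM, a difference within the usual scatter. The furthest is compound 3, which gives 14200 nM; the step here is a 5.0-fold higher number from compound 2 to compound 3 (0.70 log units; beyond the scatter), and it concerns the group on the carbonyl carbon, not the methoxy pattern on the other ring.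

Compound 4 `COc1ccc(-c2cc(/C=C/C(=O)c3ccc(N)cc3)[nH]n2)cc1OC` differs from compound 2 in one place: hydrogen in place of methoxy on an aromatic carbon.

Going by the values given here, no measured step bears directly on this change. Among the compounds with values here, the only measured step, from compound 2 to compound 3, alters a different part of the molecule and gives no guidance on methoxy count. What the data do show is that compound 1, with a single methoxy, and compound 2, with three, give values within the scatter of each other, and compound 4 lies between those two substitution patterns. The expected step is therefore none beyond the scatter, a 1.1-fold lower number from compound 2 to compound 4 (0.03 log units; within the scatter).

Compound 4 is estimated at 2700 nM, with a range from 1200 nM to 6000 nM.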

Compound 4, concentration for total growth inhibition: 13100 nM
Compound 4: middle estimate off by 4.9-fold (0.69 log units), on the low side; measured number above the stated range.
By their numbers in this assay, from the lowest: compounds 1 and 2 (each within the scatter of the next); then compounds 4 and 3 (each within the scatter of the next).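

In this assay, the aromatic carbon ortho to a methoxy group and meta to a large group proves sensitive to substitution: hydrogen in place of methoxy there gives a clear loss of growth inhibition (a 4.6-fold higher number from compound 2 to compound 4 (0.66 log units; beyond the scatter)). Methoxy in place of hydrogen, leading to compound 4 from the other side, moves the number the same way (a 5.1-fold higher number from compound 1 to compound 4 (0.71 log units; beyond the scatter)), so both single changes that arrive at compound 4 weaken growth inhibition, and the number does not follow a simple count of methoxy groups across compounds 1, 4 and 2. Nothing available explains why this substitution pattern behaves differently.

From the compounds shown here alone, it remains open whether the higher number belongs to this particular arrangement of methoxy groups or would also appear with another group at this place, such as a hydroxyl, an ethoxy group or a chlorine atom. Going by these compounds alone, it is also open whether the effect of the methoxy pattern carries over when the 4-aminophenyl group on the carbonyl carbon is replaced by 3,4-difluorophenyl, since compound 3 is the only example here with that group.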